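Shortening the Chain on a Carnitine-Like Inhibitor

The compounds below may be only part of what the source reports. "The series", "measured", "known", "first", "only" and "open" are said of these compounds alone.

Of the compounds shown here, two built on the same carnitine-like core have been measured in an assay for inhibition of carnitine O-palmitoyltransferase 1, liver isoform (Rattus norvegicus), read by radioligand binding; on this read-out lower numbers stand for stronger inhibition and higher numbers for weaker inhibition. Compound 1 `CCCCCCCCOC(=O)NC(CC(=O)[O-])C[N+](C)(C)C` carries an octyl carbamate on the core, and in this assay compound 1 gives 22300 nM. Compound 2 `CCCCCCCCCCCCCCNC(CC(=O)[O-])C[N+](C)(C)C` instead carries a tetradecyl chain on an amine nitrogen; in this assay compound 2 gives 230000 nM, the higher of the two numbers, and its gap to compound 1 lies beyond the usual scatter.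

Compound 3 `CCCCCCCCNC(CC(=O)[O-])C[N+](C)(C)C` is reached from compound 2 by one cut: hydrogen in place of hexyl on a saturated chain carbon, eight bonds along the chain from an amine nitrogen. Going by the values given here, no step between measured compounds exists for this kind of change, and compound 1 differs from compound 2 in more than one place. Shortening the chain is expected to change little, or to weaken slightly, because compound 2 already gives 230000 nM; the step from compound 2 to compound 3 is estimated at a 1.3-fold higher number from compound 2 to compound 3 (0.12 log units; within the scatter). In this assay compound 3 is therefore expected to give 300000 nM, within a range of 80000 nM to 1000000 nM.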

Compound 3, half-maximal inhibitory concentration: > 300000 nM
Compound 3 was reported as a limit; the forecaster's own chance of this, stated with the estimate: 30%; the middle value sits exactly at the limit.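

In this assay compound 3 gives > 300000 nM, which is a limit of the assay and not a number. Hydrogen in place of hexyl on a saturated chain carbon, eight bonds along the chain from an amine nitrogen, gives an at least 1.3-fold higher number from compound 2 to compound 3 (0.11 log units; that floor lies within the scatter), so this cut shows no gain in inhibition, which the earlier compounds could not show. The full size of the step cannot be read because the value of compound 3 stands at a limit: the limit of > 300000 nM in this assay, at which 1 of the 3 values shown sits.

On these data alone, whether a chain longer than tetradecyl on the amine nitrogen would lower the number remains open. So does the effect of placing an amide or a carboxylic acid on the chain of compound 3, and whether either would bring its number into a range that can be read.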